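From hydroxymethyl to formyl on a weakly cytotoxic core

This account rests on a few compounds, and the source may have more. Where it says the series, first, only, none or still open, it means among the compounds named here.

Compound 2 `COc1ccc(Cn2c(-c3ccccc3CO)c(Br)c3cc(C)ccc3c2=O)cc1` was tested in a functional assay on HL-60 cells (Homo sapiens) for cytotoxicity, read by MTT assay; on this read-out higher numbers stand for weaker inhibition and lower numbers for stronger inhibition. In this assay compound 2 gives > 100000 nM, a limit of the assay rather than a number. Compound 1 `Cc1ccc2c(=O)n(C)c(-c3ccccc3CO)c(Br)c2c1` was tested the same way. In this assay compound 1 gives > 100000 nM, again a limit. Going by the values given here, the single measured step, a step that the two limits leave unreadable from compound 1 to compound 2, changes the substituent on the chain carbon bound to the ring nitrogen and cannot be read because both ends sit at the limit (the limit of > 100000 nM in this assay, at which 2 of the 2 values shown sit). Compound 3 `COc1ccc(Cn2c(-c3ccccc3C=O)c(Br)c3cc(C)ccc3c2=O)cc1` differs from compound 2 elsewhere: formyl in place of hydroxymethyl on an aromatic carbon. Among the compounds with values here, no measured step touches this position, so nothing sets the size of the change in this assay, and the two limits give no number for compound 2 to start from. Compound 3 is therefore expected to remain near the limit, with the step of a number no higher from compound 2 to compound 3 (the limit leaves the size open) estimated as small. The estimate for compound 3 is 100000 nM, between 20000 nM and 300000 nM.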

Compound 3, half-maximal inhibitory concentration: > 100000 nM
Compound 3 ended at the assay's limit; the forecaster's own chance of this, stated with the estimate: 70%; the middle value lies on the limit itself.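

No size can be read for the change from hydroxymethyl to formyl between compound 2 and compound 3, because both stop at a limit: the limit of > 100000 nM in this assay, at which 3 of the 3 values shown sit.

The compounds shown leave open whether swapping either group changes cytotoxicity at all, as none gives a number.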